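Tracing one methyl removal across two sugar amide cores

The source may hold more compounds than are shown below. What is called first, only, known or untested is meant among the compounds shown, and "the series" means these compounds.

Compound 1 `CC[C@H](C)[C@H](NCCC1OCC(C)(C)CO1)C(=O)N[C@H]1[C@@H](OCc2ccccc2)O[C@H](COCc2ccccc2)[C@@H](OCc2ccccc2)[C@@H]1OCc1ccccc1` and compound 2 `CC(C)[C@H](NCCC1OCC(C)(C)CO1)C(=O)N[C@H]1[C@@H](OCc2ccccc2)O[C@H](COCc2ccccc2)[C@@H](OCc2ccccc2)[C@@H]1OCc1ccccc1` share a protected core and differ only in the change (hydrogen in place of methyl on a saturated chain carbon, three bonds along the chain from an amine nitrogen and a carbonyl carbon). In a functional assay on the whole organism (Ear, strain ICR) for inhibition, with Mus musculus as the target, with stated times of 30 min and 2 h, at a dose of 10 umol/kg by the oral route (a higher number here means more inhibition at the dose given (going by the name of the read-out), a lower number less inhibition), compound 1 gives 81.6%, and compound 2 gives 86.2%, so a number 4.6 percentage points higher from compound 1 to compound 2 (within the scatter). Compound 3 `CC[C@H](C)[C@H](NCCC1OCC(C)(C)CO1)C(=O)N[C@H]1C(O)O[C@H](CO)[C@@H](O)[C@@H]1O` carries a deprotected core; how it differs from compound 1 is not broken down here. In this assay compound 3 gives 88.7%. Compound 4 `CC(C)[C@H](NCCC1OCC(C)(C)CO1)C(=O)N[C@H]1C(O)O[C@H](CO)[C@@H](O)[C@@H]1O` is made from compound 3 by the same kind of change, (hydrogen in place of methyl on a saturated chain carbon, three bonds along the chain from an amine nitrogen and a carbonyl carbon), which has not yet been measured. Compound 4 is expected to give 90% in this assay, with a likely range from 80% to 98%. The estimated step of a number 1.3 percentage points higher from compound 3 to compound 4 (within the scatter) rests on the earlier step of a number 4.6 percentage points higher from compound 1 to compound 2 (within the scatter), which stayed within the scatter.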

Compound 4, a percentage reported as inhibition, in the whole organism at one dose (the size of the read-out at that dose, not a potency): 85.1%
Beside the measured number, compound 4's estimate is 4.9 percentage points above it; the range from low to high includes it.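

In this assay, replacing sec-butyl with isopropyl on the deprotected core gives a number 3.6 percentage points lower from compound 3 to compound 4 (within the scatter). Set beside the same change on the protected core, the two steps do not separate: the same change on two cores in this assay, a number 4.6 percentage points higher (within the scatter) from compound 1 to compound 2 and a number 3.6 percentage points lower (within the scatter) from compound 3 to compound 4, 8.2 percentage points apart, within the scatter of two such steps Within these two pairs, the change therefore stays inside the scatter on both cores, and the opposite directions of the steps carry no weight; this does not show that the change is without effect in general, as the read-out comes from a single dose and is not a potency.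

The compounds shown leave open whether a longer chain, a phenyl ring or a carboxylic acid in place of the sec-butyl would give a step beyond the scatter. They also leave open whether these four compounds would separate at other doses.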